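Chlorine on the phenyl ring and paw edema inhibition

The source may report more compounds than this note shows. Statements on the series, on what has been measured and on what is new or still open speak of the compounds shown alone.

The measured compounds:
Compound 1, `N#Cc1c(-c2ccccc2)nc(SCC(=O)Nn2c(COc3ccc(Cl)cc3Cl)nc3ccccc3c2=O)[nH]c1=O`, gives 86% in a functional assay on the whole organism (strain albino) for inhibition, with Rattus norvegicus as the target, read by paw edema, with stated times of 1 h and 3 h, at a dose of 100 mg/kg by the oral route; a higher number here means a stronger effect of the compound at the dose given, a lower number a weaker effect.
Compound 2, `N#Cc1c(-c2ccc(Cl)cc2)nc(SCC(=O)Nn2c(COc3ccc(Cl)cc3Cl)nc3ccccc3c2=O)[nH]c1=O`, gives 64.9%.
Compound 3, `N#Cc1c(Nc2ccccc2)nc(SCC(=O)Nn2c(COc3ccc(Cl)cc3Cl)nc3ccccc3c2=O)nc1-c1ccccc1`, gives 78.1%.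

Compound 1 and compound 2 share one core and differ in a single place: chloro in place of hydrogen on an aromatic carbon. This change made a number 21.1 percentage points lower from compound 1 to compound 2 (beyond the scatter). Compound 3 belongs to a second core; how its core differs from that of compound 1 is not broken down here. Compared with compound 1, the value of compound 3 lies within the scatter; compared with compound 2, it lies higher by an amount beyond the scatter.

Compound 4, `N#Cc1c(Nc2ccccc2)nc(SCC(=O)Nn2c(COc3ccc(Cl)cc3Cl)nc3ccccc3c2=O)nc1-c1ccc(Cl)cc1`, has not yet been measured. It stands to compound 3 as compound 2 stands to compound 1: chloro in place of hydrogen on an aromatic carbon. The place of the change reads the same in both pairs, so this is the same kind of change on a different core. On the first core it lowered the read-out by a modest amount; on the second core nothing is known yet. For the measured compounds named here, because the only measured step for this change is a number 21.1 percentage points lower from compound 1 to compound 2 (beyond the scatter), a step of a similar size is expected here: the estimate is a number 20.1 percentage points lower from compound 3 to compound 4 (beyond the scatter). Compound 4 is therefore expected to give 58%, with an expected range from 44% to 72%.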

Compound 4, a percentage reported as inhibition, in the whole organism at one dose (the size of the read-out at that dose, not a potency): 56.1%
Estimate against measurement, compound 4: 1.9 percentage points above; measured number inside the range.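

The change from phenyl to 4-chlorophenyl gave a number 22 percentage points lower from compound 3 to compound 4 (beyond the scatter) in this assay, so the loss seen on the first core appeared again on the second. The two steps cannot be told apart in size, and in these two pairs the effect of this change carried over from one core to the other: the same change on two cores in this assay, a number 21.1 percentage points lower (beyond the scatter) from compound 1 to compound 2 and a number 22 percentage points lower (beyond the scatter) from compound 3 to compound 4, 0.9 percentage points apart, within the scatter of two such steps

This does not show that the step would keep its size on any further core, since the comparison rests on two pairs, and it gives no reason for the loss. As the read-out comes from a single dose, it also says nothing about a shift in potency.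

The compounds shown leave open whether a fluoro, methyl or methoxy group on the same aromatic carbon would lower the inhibition of paw edema as chloro does. They also leave open whether a chloro group at another place on that ring, or a second chloro group, would give a step of like size on either core.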